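A few compounds are considered here, and "the series" means these few. Any claim that something is new, unique, unknown or untested is made for them only; others in the source may bear on it.

For the measured compounds named here, in an assay on membranes from Cortex for displacement of a labelled ligand from Sigma non-opioid intracellular receptor 1 (Cavia porcellus), read by scintillation counting, with a stated time of 120 min (a lower number here means a stronger inhibitor, a higher number a weaker inhibitor), compound 1 `O=C(c1ccccc1)N1CCC(NCCSC(c2ccc(F)cc2)c2ccc(F)cc2)CC1` gives 2.03 nM and compound 2 `Fc1ccc(C(SCCNC2CCN(CC3CC3)CC2)c2ccc(F)cc2)cc1` gives 269 nM; the single measured step, a 130-fold higher number from compound 1 to compound 2 (2.12 log units; beyond the scatter), is large. Going by the values given here, compound 2 therefore holds the highest of the two numbers, with compound 1 as its only neighbour. Compound 3 `CC(C)(C)CN1CCC(NCCSC(c2ccc(F)cc2)c2ccc(F)cc2)CC1` differs from compound 2 by tert-butyl in place of cyclopropyl on a saturated chain carbon bound to an amine nitrogen in a ring. Among the compounds with values here, the one step in hand replaced benzoyl with cyclopropylmethyl, a change of a different kind; no measured step swaps one alkyl for another, so no direction is indicated. For compound 3 only a step within the scatter is expected, a 1.1-fold higher number from compound 2 to compound 3 (0.05 log units; within the scatter). Compound 3 is estimated at 300 nM in this assay, range 100 nM to 900 nM.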

Compound 3, inhibition constant: 315 nM
Compound 3: middle estimate off by 1.1-fold (0.02 log units), on the low side; low and high end bracket the measured number.
By their numbers in this assay, from the lowest: compound 1; then compounds 2 and 3 (each within the scatter of the next).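

In this assay, tert-butyl in place of cyclopropyl on a saturated chain carbon bound to an amine nitrogen in a ring gives a 1.2-fold higher number from compound 2 to compound 3 (0.07 log units; within the scatter), so these two alkyl ends are not told apart here. Neopentyl in place of benzoyl gives a 160-fold higher number from compound 1 to compound 3 (2.19 log units; beyond the scatter), so the large gap to compound 1 holds for compound 2 and for compound 3 alike. Nothing at hand gives a cause for either step. Which part of benzoyl carries the gap remains open. A benzyl or an acetyl group on that amine nitrogen would bear on this.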